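The source may hold more compounds than are shown below. What is called first, only, known or untested is meant among the compounds shown, and "the series" means these compounds.

Measured compounds:
compound 1, `Nc1nc(Cl)c2ncn(Cc3ccc(CCl)cc3)c2n1`, gives 25700 nM in a functional assay on NCI-H522 cells (Homo sapiens) for cytotoxicity, read by sulforhodamine B assay, with a stated time of 48 h; on this read-out higher numbers stand for weaker inhibition of growth and lower numbers for stronger inhibition of growth
compound 2, `ClCc1cccc(Cn2cnc3c(Cl)nc(Cl)nc32)c1`, gives 5370 nM in this assay
compound 3, `ClCc1ccc(Cn2cnc3c(Cl)nc(Cl)nc32)cc1`, gives 46800 nM in this assay

Compound 1 and compound 3 share a core and differ by one change, (amino in place of chloro on an aromatic carbon). That change gave a 1.8-fold lower number from compound 3 to compound 1 (0.26 log units; within the scatter). Compound 2 and compound 3 are built from the same atoms joined differently; the difference between the two cores is not broken down here. Compound 2 shows the lowest number of the three, separated from each of the others by more than the usual scatter.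

Compound 4, `Nc1nc(Cl)c2ncn(Cc3cccc(CCl)c3)c2n1`, is not yet measured. It differs from compound 2 by amino in place of chloro on an aromatic carbon, the same change already seen from compound 3 to compound 1. Because that earlier step was a 1.8-fold lower number from compound 3 to compound 1 (0.26 log units; within the scatter), a step of about a 1.4-fold lower number from compound 2 to compound 4 (0.15 log units; within the scatter) is expected here in this assay. Compound 4 is therefore estimated at 3800 nM, expected to fall between 1500 nM and 10000 nM.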

Compound 4, concentration for total growth inhibition: 13500 nM
Beside the measured number, compound 4's estimate is 3.6-fold (0.55 log units) below it, outside the stated range (above it).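

Putting amino in place of chloro on the core of compound 2 gave a 2.5-fold higher number from compound 2 to compound 4 (0.40 log units; beyond the scatter) in this assay. Set beside the earlier step, the same change did not carry over unchanged from one core to the other: the same change on two cores in this assay, a 1.8-fold lower number (0.26 log units; within the scatter) from compound 3 to compound 1 and a 2.5-fold higher number (0.40 log units; beyond the scatter) from compound 2 to compound 4, 4.6-fold (0.66 log units) apart, beyond the scatter of two such steps. So in this assay, a step read on one core cannot simply be transferred to the other, but these two pairs do not show why the cores differ and set no rule for the wider series.

The compounds shown leave open how a methylamino or methoxy group would behave in place of that chloro on either core. Also open, as far as these compounds go, is what a hydroxymethyl group would do in place of the chloromethyl group.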